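Moving a Methyl Around the Ring: Compound 1 to Compound 4

The source may hold more compounds than are shown below. What is called first, only, known or untested is meant among the compounds shown, and "the series" means these compounds.

Three compounds share a common core carrying a hydroxamic acid and have been tested in an assay on Sf9 cells for inhibition of protein deacetylase HDAC6 (Homo sapiens), read by fluorescence, with a stated time of 40 min, tested at 100 nM; on this read-out higher numbers stand for more inhibition at the one concentration tested (going by the name of the read-out) and lower numbers for less inhibition. Compound 1 `Cc1cccc(-c2nc(CNc3ccc(C(=O)NO)cc3)n(-c3ccccc3)n2)c1` gives 64.1% and stands second of the three. Compound 2 `O=C(NO)c1ccc(NCc2nc(-c3cccs3)nn2-c2ccc(O)cc2)cc1` gives 79.6%, a higher number than compound 1 by a margin beyond the usual scatter. Compound 3 `CCc1ccc(-n2nc(-c3ccccc3)nc2CNc2ccc(C(=O)NO)cc2)cc1` gives 38.3%, a lower number than compound 1, again by a margin beyond the scatter.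

Compound 4 `Cc1ccccc1-c1nc(CNc2ccc(C(=O)NO)cc2)n(-c2ccccc2)n1` has not yet been measured in this assay. It differs from compound 1 in a single place: 2-methylphenyl in place of 3-methylphenyl on an aromatic carbon. The two compounds contain the same atoms, joined differently, so the change is only in where the methyl sits on the phenyl ring.

Going by the values given here, with no step between measured compounds that isolates this kind of change, the expectation rests on the small size of the alteration. Compound 4 is expected to give about 58%, within a range from 40% to 75%. This estimate means an expected step of a number 6.1 percentage points lower from compound 1 to compound 4 (within the scatter), which would stay within the usual scatter of the measurement.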

Compound 4, a percentage reported as inhibition, at one concentration (the size of the read-out at that concentration, not a potency): 53.2%
The estimate for compound 4 lay 4.8 percentage points above the measured number; low and high end bracket the measured number.
By their numbers in this assay, from the lowest: compound 3; then compound 4; then compound 1; then compound 2.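

In this assay, moving the methyl so that 2-methylphenyl replaces 3-methylphenyl gives a number 10.9 percentage points lower from compound 1 to compound 4 (beyond the scatter) and so shows that the read-out responds to where this methyl sits, even though the atoms stay the same. Compounds 1, 2 and 3 could not show this, since none of them differs from another in one place only. Going by these compounds alone, this modest step is the first direct reading for the aryl group on this aromatic carbon, but no available measurement explains it.

The compounds shown leave open how the read-out would respond to an amine or a carboxylic acid in place of the methyl on this phenyl ring. They also leave open whether the same shift of the methyl would give a step of similar size if the other phenyl group carried a substituent such as ethyl.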